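Piperidin-4-yl in Place of Hydrogen on Compound 2

This account rests on a few compounds, and the source may have more. Where it says the series, first, only, none or still open, it means among the compounds named here.

Among the measured compounds shown here, compound 2 `c1ccc2c(-c3cocn3)c[nH]c2c1` stands at the top of the two numbers measured so far: in a functional assay on DU-145 cells (Homo sapiens) for cytotoxicity, read by MTT assay, with a stated time of 48 h (on this read-out higher numbers stand for weaker inhibition and lower numbers for stronger inhibition), compound 2 gives 93500 nM, whereas compound 1 `Fc1ccc(-c2nc(-c3c[nH]c4ccccc34)co2)cc1` gives 31800 nM. For the measured compounds named here, the single step that links them, a 2.9-fold higher number from compound 1 to compound 2 (0.47 log units; beyond the scatter), lies beyond the scatter and is the only measured step available.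

Compound 3 `c1ccc2c(-c3coc(C4CCNCC4)n3)c[nH]c2c1` is not yet measured. It differs from compound 2 by piperidin-4-yl in place of hydrogen on an aromatic carbon. The step that bears on this change is a 2.9-fold higher number from compound 1 to compound 2 (0.47 log units; beyond the scatter), which shows that a larger group in place of hydrogen on that aromatic carbon went with a lower number in this assay. Compound 3 carries a different group there, so only the direction, not the size, can be carried over with confidence, and a downward step of modest size is expected rather than none beyond the scatter. Compound 3 is therefore estimated at 40000 nM in this assay, with a range from 15000 nM to 110000 nM. The expected step is a 2.3-fold lower number from compound 2 to compound 3 (0.37 log units; beyond the scatter).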

Compound 3, half-maximal inhibitory concentration: 381000 nM
Beside the measured number, compound 3's estimate is 9.5-fold (0.98 log units) below it, and the stated range ends below it.
By their numbers in this assay, from the lowest: compound 1; then compound 2; then compound 3.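

In this assay the aromatic carbon next to the ring nitrogen and next to the ring oxygen does not respond to substitution in a single direction: piperidin-4-yl in place of hydrogen gives a 4.1-fold higher number from compound 2 to compound 3 (0.61 log units; beyond the scatter) while the earlier step, a 2.9-fold higher number from compound 1 to compound 2 (0.47 log units; beyond the scatter), showed that 4-fluorophenyl goes with a lower number than hydrogen. Exchanging one group for the other at this carbon gives a 12-fold higher number from compound 1 to compound 3 (1.08 log units; beyond the scatter), the largest step among the three compounds, so what matters here is which group enters and not merely that hydrogen leaves. No measurement shown accounts for why these two groups part in opposite directions.

From the compounds shown here alone, whether the ring nitrogen of piperidin-4-yl goes with the higher number stays open, and cyclohexyl, the same six-membered ring with carbon in place of that nitrogen, would separate the ring from its nitrogen at this carbon. Phenyl without the fluorine, or a 1-methylpiperidin-4-yl group, would likewise show how far each of the two measured groups depends on that single atom or on the hydrogen on its nitrogen.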